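The compounds below may be only part of what the source reports. "The series", "measured", "known", "first", "only" and "open" are said of these compounds alone.

Compound 1 `C[C@@H](NCc1ccc(OCc2ccccc2)cc1)C(N)=O`: 23.8 mg/kg
Compound 2 `C[C@@H](NCc1ccc(OCc2ccccc2Cl)cc1)C(N)=O`: 17.4 mg/kg

In a functional assay on the whole organism with Mus musculus as the target (a higher number here means that more compound is needed for the effect, a lower number that less compound is needed), compound 2 gives 17.4 mg/kg and compound 1 gives 23.8 mg/kg, two values within the scatter of each other. Going by the values given here, these are the only measurements so far, so compound 2 cannot be separated from compound 1. In compound 3 `C[C@@H](NCc1ccc(OCc2ccc(F)cc2)cc1)C(N)=O`, still unmeasured, 4-fluorophenyl stands in place of 2-chlorophenyl on a saturated chain carbon bound to an oxygen on an aromatic ring (4-fluorophenyl in place of 2-chlorophenyl on a saturated chain carbon bound to an oxygen on an aromatic ring). Among the compounds with values here, one measured step bears on this change: a 1.4-fold lower number from compound 1 to compound 2 (0.14 log units; within the scatter), where chloro replaced hydrogen on an aromatic carbon. That step stays within the scatter. Within the data shown here, no measured compound carries fluoro, so the data do not test that group directly. In this assay, no change beyond the scatter is therefore expected, and the estimated step is a 1.2-fold lower number from compound 2 to compound 3 (0.06 log units; within the scatter). Compound 3 is expected at 15 mg/kg, with an estimated range of 7 mg/kg to 30 mg/kg.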

Compound 3, dose for half-maximal effect: 132 mg/kg
Compound 3: middle estimate off by 8.8-fold (0.94 log units), on the low side, and the stated range ends below it.
By their numbers in this assay, from the lowest: compounds 2 and 1 (each within the scatter of the next); then compound 3.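

The earlier compounds shown here gave no sign that a substituent on this phenyl ring could matter in this assay, since chloro in place of hydrogen gave only a 1.4-fold lower number from compound 1 to compound 2 (0.14 log units; within the scatter). This ring is now shown not to be indifferent to substitution: fluoro in place of hydrogen gives a 5.5-fold higher number from compound 1 to compound 3 (0.74 log units; beyond the scatter), so more compound is needed. Replacing 2-chlorophenyl with 4-fluorophenyl gives a 7.6-fold higher number from compound 2 to compound 3 (0.88 log units; beyond the scatter), so the two substituted rings are clearly separated, although this change alters both the halogen and its place on the ring. No measurement on hand accounts for this difference.

The compounds shown therefore leave open whether the halogen or its place on the ring governs the step, a question that 4-chlorophenyl and 2-fluorophenyl would separate. On these data alone, how a methoxy group would behave on this ring also remains open.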